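Replacing the 4-cyanophenyl group of compound 3 with cyclohexyl

A few compounds are considered here, and "the series" means these few. Any claim that something is new, unique, unknown or untested is made for them only; others in the source may bear on it.

In a functional assay on OCI-Ly3 cells (Homo sapiens) for inhibition, read by CellTiter-Glo, with stated times of 48 h and 96 h (on this read-out higher numbers stand for weaker inhibition of growth and lower numbers for stronger inhibition of growth), compound 1 `CC(C)[C@H](NC(=O)c1ccccc1)C(=O)N1CCC[C@H]1C(=O)N[C@@H](CCCNC(=N)N)C(=O)CF` gives 660 nM, compound 2 `CC(C)[C@H](NC(=O)c1ccccc1Br)C(=O)N1CCC[C@H]1C(=O)N[C@@H](CCCNC(=N)N)C(=O)CF` gives 4240 nM and compound 3 `CC(C)[C@H](NC(=O)c1ccc(C#N)cc1)C(=O)N1CCC[C@H]1C(=O)N[C@@H](CCCNC(=N)N)C(=O)CF` gives 6660 nM. Compound 3 stands level with compound 2, with a 1.6-fold higher number from compound 2 to compound 3 (0.20 log units; within the scatter) lying within the scatter, and clearly apart from compound 1, with a 10-fold higher number from compound 1 to compound 3 (1.00 log units; beyond the scatter) lying beyond it.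

Compound 4 `CC(C)[C@H](NC(=O)C1CCCCC1)C(=O)N1CCC[C@H]1C(=O)N[C@@H](CCCNC(=N)N)C(=O)CF` carries cyclohexyl in place of 4-cyanophenyl on a carbonyl carbon. Going by the values given here, two measured steps bear on this change: adding a group to the aromatic ring of compound 1 gave a 6.4-fold higher number from compound 1 to compound 2 (0.81 log units; beyond the scatter) with bromo and a 10-fold higher number from compound 1 to compound 3 (1.00 log units; beyond the scatter) with cyano. Compound 4 no longer has the cyano group, which points back toward compound 1. Among the compounds with values here, no measured pair replaces an aromatic ring with a non-aromatic one, so that part of the change remains untested, and only a partial return is assumed. The expected result is a 3.3-fold lower number from compound 3 to compound 4 (0.52 log units; beyond the scatter), a modest move toward a lower number. For compound 4 the estimated value is 2000 nM, with an expected range of 600 nM to 7000 nM.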

Compound 4, concentration for 50% growth inhibition: 940 nM
Compound 4: the middle estimate sits 2.1-fold (0.33 log units) above what was measured; the range from low to high includes it.
By their numbers in this assay, from the lowest: compounds 1 and 4 (each within the scatter of the next); then compounds 2 and 3 (each within the scatter of the next).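

In this assay the place on the carbonyl carbon accepts a non-aromatic ring: cyclohexyl and phenyl stand level, with a 1.4-fold higher number from compound 1 to compound 4 (0.15 log units; within the scatter) lying within the scatter, so an aromatic ring is not needed here for the lowest numbers in this set. Removing the substituted aromatic ring pays off, with a 7.1-fold lower number from compound 3 to compound 4 (0.85 log units; beyond the scatter) and a 4.5-fold lower number from compound 2 to compound 4 (0.65 log units; beyond the scatter) both beyond the scatter, so compounds 1 and 4, which carry neither bromo nor cyano, stand apart from compounds 2 and 3. No evidence is available on the origin of these differences.

From the compounds shown here alone, whether a cyclohexyl ring bearing a substituent would follow compound 4 or compounds 2 and 3 remains open. Also open, going by these compounds, is whether a cyclopropyl group, a straight hexyl chain or a ring carrying an amine would stay level with compound 1.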